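A few compounds are considered here, and "the series" means these few. Any claim that something is new, unique, unknown or untested is made for them only; others in the source may bear on it.

Measured so far:
compound 1 `N#CN/C(=N\C1CCCC1)Nc1cc(Cl)cc(Cl)c1` — 12000 nM
compound 2 `CC(C)CC/N=C(\NC#N)Nc1cc(C(F)(F)F)cc(C(F)(F)F)c1` — 4700 nM

In a functional assay on Beta-TC3 cells (Rattus norvegicus) with Beta-TC3 (Mus musculus) as the target, using a membrane potential dye (on this read-out lower numbers stand for stronger inhibition and higher numbers for weaker inhibition), compound 2 gives the lower of the two numbers; compound 1 gives a number above it, beyond the scatter. Compound 3 `CCC/N=C(\NC#N)Nc1cc(C(F)(F)F)cc(C(F)(F)F)c1` is not yet measured and differs from compound 2 by methyl in place of isopropyl on a saturated chain carbon, two bonds along the chain from a double-bonded nitrogen. Within the data shown here, no measured pair covers such a change, so the step from compound 2 to compound 3 in this assay is expected to be modest and towards a higher number, at about the edge of the scatter. Compound 3 is expected at 9000 nM, with a range from 3000 nM to 30000 nM, which means a 1.9-fold higher number from compound 2 to compound 3 (0.28 log units; within the scatter).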

Compound 3, half-maximal inhibitory concentration: 19000 nM
Estimate against measurement, compound 3: 2.1-fold (0.32 log units) below, within the range that was stated.
By their numbers in this assay, from the lowest: compound 2; then compounds 1 and 3 (each within the scatter of the next).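

In this assay, methyl in place of isopropyl at this saturated chain carbon gives a 4.0-fold higher number from compound 2 to compound 3 (0.61 log units; beyond the scatter), so on this core the isopentyl to propyl change is not neutral. Among these compounds, the step is the first one read at this position, and it takes the number upward as the chain is cut back. Nothing on hand bears on what lies behind the step. Going by these compounds, one step cannot separate chain length from branching: whether an unbranched pentyl chain matches isopentyl, and whether a longer chain such as hexyl lowers the number further, stay open.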